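A few compounds are considered here, and "the series" means these few. Any claim that something is new, unique, unknown or untested is made for them only; others in the source may bear on it.

Measured compounds:
- compound 1 `CNC(=O)c1cc(Oc2ccc(C(=O)/C=C/c3ccc([N+](=O)[O-])cc3)cc2)ccn1`: "not determined" (no result reported)
- compound 2 `CNC(=O)c1cc(Oc2ccc(C(=O)/C=C/c3ccc(F)cc3)cc2)ccn1`: 12600 nM
- compound 3 `CNC(=O)c1cc(Oc2ccc(C(=O)/C=C/c3ccc(OC)cc3)cc2)ccn1`: "not determined" (no result reported)

In a functional assay on HepG2 cells (Homo sapiens) for cytotoxicity, read by MTT assay, with a stated time of 72 h (a higher number here means a weaker inhibitor, a lower number a stronger inhibitor), only compound 2 carries a number, 12600 nM. For compound 1 the entry reads "not determined" (no result reported), and for compound 3 it reads "not determined" (no result reported), so compound 3 stands on no number at all, and one further entry in the set is likewise without a number. For the measured compounds named here, no pair of measured compounds that differ in one place is available, so no step size has been seen.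

Compound 4 `CNC(=O)c1cc(Oc2ccc(C(=O)/C=C/c3cccc([N+](=O)[O-])c3)cc2)ccn1` differs from compound 3 as follows: 3-nitrophenyl in place of 4-methoxyphenyl on a double-bonded chain carbon bound to a double-bonded chain carbon. The expectation for this change in this assay cannot be anchored on compound 3, which has no value. Going by the values given here, the only number in the set is that of compound 2, 12600 nM, and the series as a whole is so far weakly active there. A step of no more than the usual scatter in either direction is expected, given that nothing in the data points one way.

Compound 4 is therefore estimated at 12000 nM in this assay, with a range from 3000 nM to 45000 nM, and a fair chance that only a limit is reported.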

Compound 4, half-maximal inhibitory concentration: > 50000 nM
Compound 4: a limit, no number (the forecaster's own chance of this, stated with the estimate: 25%); at least 4.1-fold (0.61 log units) between middle value and limit.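

In this assay, this chain carbon is sensitive to the choice of aryl group: 3-nitrophenyl in place of 4-fluorophenyl gives an at least 3.9-fold higher number from compound 2 to compound 4 (0.59 log units; beyond the scatter), the first step seen in the series and one beyond the scatter. Compound 4 gives > 50000 nM, which is a limit and not a number, so the step has a lower bound but no fixed size. This is the only reading of its kind in the set: the limit of > 50000 nM in this assay, at which 1 of the 4 values shown sits.

Steps to or from compound 1 and compound 3 cannot be read, so the data do not show whether the nitro group itself or its place on the phenyl ring accounts for the step from 4-fluorophenyl to 3-nitrophenyl. Also open, as far as these compounds go, is whether a phenyl ring carrying a dimethylamino group or a carboxylic acid at this chain carbon would give a number in this assay, and on which side of the fluorine-bearing compound 2 that number would fall.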